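Ethylphenyl sulfonamides: moving from compound 3 to compound 4

The source may hold more compounds than are shown below. What is called first, only, known or untested is meant among the compounds shown, and "the series" means these compounds.

Values in a functional assay on HT-29 cells (Homo sapiens) for antiproliferative activity, read by sulforhodamine B assay, with a stated time of 48 h; a higher number here means a weaker inhibitor, a lower number a stronger inhibitor:
- compound 1 `CCc1ccccc1NS(=O)(=O)c1ccc(N2CCNC2=O)cc1`: 240 nM
- compound 2 `Cc1ccc(NS(=O)(=O)c2ccc(N3CCNC3=O)cc2)cc1`: 480 nM
- compound 3 `CCc1ccc(NS(=O)(=O)c2ccc(N3CCNC3=O)cc2)cc1`: 660 nM

Compound 3 carries the highest of the three numbers, although compound 2 cannot be separated from it: the data show a 1.4-fold higher number from compound 2 to compound 3 (0.14 log units; within the scatter). The gap to compound 1 is larger, at a 2.8-fold higher number from compound 1 to compound 3 (0.44 log units; beyond the scatter).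

Compound 4 `CCc1cccc(NS(=O)(=O)c2ccc(N3CCNC3=O)cc2)c1` is still to be measured in this assay. The change is 3-ethylphenyl in place of 4-ethylphenyl on a sulfonamide nitrogen, so the atoms stay the same and only their joining differs.

The nearest measured precedent is a 2.8-fold higher number from compound 1 to compound 3 (0.44 log units; beyond the scatter), also an exchange of one ethylphenyl group for another on the sulfonamide nitrogen, and it is modest. The other swap on that nitrogen, a 2.0-fold higher number from compound 1 to compound 2 (0.30 log units; within the scatter), is smaller. Within the data shown here, no measured compound carries 3-ethylphenyl, so the direction rests on little. A small move toward a lower number is expected, not one beyond the scatter.

The estimated step is a 1.5-fold lower number from compound 3 to compound 4 (0.17 log units; within the scatter). For compound 4 the expected value is 450 nM, with an estimated range of 200 nM to 1000 nM.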

Compound 4, half-maximal inhibitory concentration: 110 nM
For compound 4 the middle estimate is 4.1-fold (0.61 log units) above the measured one; the whole stated range lies above it.
By their numbers in this assay, from the lowest: compound 4; then compounds 1, 2 and 3 (each within the scatter of the next, the first and the last beyond it).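

In this assay, among these compounds, where the ethyl group sits on the phenyl ring on the sulfonamide nitrogen matters more than the earlier compounds could show: with the atoms unchanged, 3-ethylphenyl in place of 4-ethylphenyl gives a 6.0-fold lower number from compound 3 to compound 4 (0.78 log units; beyond the scatter), the largest step in the set. Among the compounds shown here, the same group also gives a 2.2-fold lower number from compound 1 to compound 4 (0.34 log units; beyond the scatter) and a 4.4-fold lower number from compound 2 to compound 4 (0.64 log units; beyond the scatter), so compound 4 is the strongest inhibitor of the four, whereas the earlier compounds gave no clear separation between 4-methylphenyl and either ethylphenyl neighbour. For the compounds shown here, nothing at hand explains why this rearrangement moves the number so far.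

From the compounds shown here alone, whether a longer chain, an amine or a carboxylic acid in place of the ethyl group of 3-ethylphenyl would keep the low number remains open. Going by these compounds, whether the order of the four compounds holds outside this single cell line is also open.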